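The source may hold more compounds than are shown below. What is called first, only, known or untested is meant among the compounds shown, and "the series" means these compounds.

Within the data shown here, compound 1 `COC(=O)N1N=C(c2ccccc2)CC1c1cc(OC)c(OC)c(OC)c1` gives 2770 nM in a functional assay on A2780 cells (Homo sapiens) for antiproliferative activity, read by MTT assay, with a stated time of 48 h (on this read-out lower numbers stand for stronger inhibition of growth and higher numbers for weaker inhibition of growth), the only actual number so far. Compound 2 `COc1cc(C2CC(c3ccccc3)=NN2C(=O)OCc2ccccc2)cc(OC)c1OC` reaches only a limit in this assay, > 10000 nM. Compound 3 `COC(=O)N1N=C(c2ccc(OC)cc2)CC1c1cc(OC)c(OC)c(OC)c1` differs from compound 1 on an aromatic carbon, where methoxy replaces hydrogen, turning phenyl into 4-methoxyphenyl: methoxy in place of hydrogen on an aromatic carbon. Among the measured compounds shown here, the one measured step, an at least 3.6-fold higher number from compound 1 to compound 2 (0.55 log units; beyond the scatter), falls instead on a saturated chain carbon bound to an oxygen next to a carbonyl group, so it sets no direction for this change, and no step beyond the scatter is expected in this assay. The estimated step is a 1.1-fold lower number from compound 1 to compound 3 (0.04 log units; within the scatter). For compound 3 the estimated value is 2500 nM, with a range from 700 nM to 9000 nM.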

Compound 3, concentration for 50% growth inhibition: 5000 nM
For compound 3 the middle estimate is 2.0-fold (0.30 log units) below the measured one; measured number inside the range.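

In this assay, the change from phenyl to 4-methoxyphenyl gives a 1.8-fold higher number from compound 1 to compound 3 (0.26 log units; within the scatter). Among these compounds, this is the first view of this aromatic carbon, and it shows that methoxy can replace hydrogen there without a change beyond the scatter, unlike the earlier step on the saturated chain carbon. No information shown here bears on a cause for this result. From the compounds shown here alone, it remains open whether an amine, a carboxylic acid or a longer chain such as butoxy at this place would also stay within the scatter of compound 1.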